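The source may report more compounds than this note shows. Statements on the series, on what has been measured and on what is new or still open speak of the compounds shown alone.

Working notes on the series.

Two compounds share the same core and differ only in the group on the amide-type nitrogen. Compound 1 `COc1ccc(CNC(=O)/C=C/c2coc3cc(OC)ccc3c2=O)cc1` carries a 4-methoxybenzyl group there, and in a functional assay on A549 cells (Homo sapiens) for inhibition, read by MTT assay, with a stated time of 48 h (a higher number here means a weaker inhibitor, a lower number a stronger inhibitor), compound 1 gives 22500 nM. Compound 2 `COc1ccc2c(=O)c(/C=C/C(=O)Nc3ccccc3C)coc2c1` carries a 2-methylphenyl group instead, and in this assay compound 2 gives 23400 nM. The step of a 1.0-fold higher number from compound 1 to compound 2 (0.02 log units; within the scatter) shows that this exchange of the nitrogen substituent left the read-out essentially unchanged. On the numbers available, compound 2 stands with the higher of the two values, but its gap to compound 1 lies within the scatter, so no order can be read from it.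

Compound 3 `COc1ccc2c(=O)c(/C=C/C(=O)Nc3ccc(Cl)cc3)coc2c1` is not yet measured. The change from compound 2 is 4-chlorophenyl in place of 2-methylphenyl on an amide-type nitrogen. Within the data shown here, the only measured step that bears on it is the one between compound 1 and compound 2 at the same position, and it was within the scatter. On that basis, the step of a 1.0-fold lower number from compound 2 to compound 3 (0.01 log units; within the scatter) is expected to remain within the scatter, with no clear direction. In this assay compound 3 is therefore estimated at 23000 nM, with a plausible range from 9000 nM to 60000 nM.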

Compound 3, half-maximal inhibitory concentration: > 100000 nM
Compound 3: only a limit was reported; the forecaster's own chance of this, stated with the estimate: 10%; middle value at least 4.3-fold (0.63 log units) away from the limit.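

Compound 3 is reported in this assay only as a limit, not as a number: the limit of > 100000 nM in this assay, at which 1 of the 3 values shown sits.

The earlier pair suggested that the amide-type nitrogen tolerated exchange, but this position is not indifferent to its substituent: 4-chlorophenyl gives an at least 4.2-fold higher number from compound 2 to compound 3 (0.63 log units; beyond the scatter) and an at least 4.4-fold higher number from compound 1 to compound 3 (0.64 log units; beyond the scatter), both beyond the scatter and both towards a weaker inhibitor. The exchange of 2-methylphenyl for 4-chlorophenyl keeps the count of heavy atoms, the single six-membered aromatic ring and the absence of hydrogen-bond donors and acceptors, so these counts do not separate compound 2 from compound 3, although the read-out does.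

The compounds shown leave open whether the difference follows the chlorine or the place of the substituent on the phenyl ring, a question that 4-methylphenyl and 2-chlorophenyl groups on the same nitrogen would separate. They also leave open how the read-out responds to a phenyl ring without a substituent, or to one carrying an amine or a carboxylic acid, and how far compound 3 really lies from compound 1 and compound 2.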